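Piperazine urea series: nitro analogue of compound 2

A few compounds are considered here, and "the series" means these few. Any claim that something is new, unique, unknown or untested is made for them only; others in the source may bear on it.

Measured so far:
compound 1 `CC(C)c1ccc(NC(=O)N2CCN(c3ncccc3Cl)CC2)cc1` — 17.3 nM
compound 2 `O=C(Nc1ccc(OC(F)(F)F)cc1)N1CCN(c2ncccc2Cl)CC1` — 261 nM

Working notes. In a functional assay on HEK293 cells for antagonist activity at transient receptor potential cation channel subfamily V member 1 (Rattus norvegicus) (on this read-out lower numbers stand for stronger inhibition and higher numbers for weaker inhibition), compound 1 gives 17.3 nM and compound 2 gives 261 nM. For the measured compounds named here, compound 2 therefore stands highest of the two numbers known so far; its nearest neighbour is compound 1, and the single step between them, a 15-fold higher number from compound 1 to compound 2 (1.18 log units; beyond the scatter), is the only measured step.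

Compound 3 `O=C(Nc1ccc([N+](=O)[O-])cc1)N1CCN(c2ncccc2Cl)CC1` is next. Relative to compound 2 the change is nitro in place of trifluoromethoxy on an aromatic carbon. Going by the values given here, no measured step involves a nitro group, so the only precedent is the swap at the same position that separates compound 1 from compound 2, which was large and unfavourable. That step does not carry over directly, and the expectation for compound 3 is a modest, uncertain move, a 1.5-fold higher number from compound 2 to compound 3 (0.19 log units; within the scatter), broadly around the level of compound 2. For compound 3 the estimated value in this assay is 400 nM, with a range from 100 nM to 1600 nM.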

Compound 3, half-maximal inhibitory concentration: > 25000 nM
Compound 3: a limit, no number (the forecaster's own chance of this, stated with the estimate: 5%); middle value at least 62-fold (1.79 log units) from the limit.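

In this assay compound 3 gives > 25000 nM, which is a limit of the assay and not a number. Nitro in place of trifluoromethoxy gives an at least 95-fold higher number from compound 2 to compound 3 (1.98 log units; beyond the scatter), and nitro in place of isopropyl gives an at least 1400-fold higher number from compound 1 to compound 3 (3.15 log units; beyond the scatter), so the substituent on this aromatic carbon, para to a large group, can take the read-out from a measurable inhibition to the assay limit, a wider span than the earlier step alone showed. Across these three compounds, with the rest of the structure unchanged, the numbers rise from isopropyl through trifluoromethoxy to nitro.

The compounds shown do not tell which feature of the nitro group goes with this loss. An amine, a nitrile or a tert-butyl group at the same place would show how far the trend extends beyond these three groups.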